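Dropping the methyl: from compound 3 to compound 4

The source may hold more compounds than are shown below. What is called first, only, known or untested is meant among the compounds shown, and "the series" means these compounds.

Among the three measured compounds, compound 3 `Cc1ccccc1Nc1nc(SCc2cn(Cc3ccccc3Cl)nn2)nc(-c2ccccc2)c1C#N` gives the lowest number in a functional assay on B16-F10 cells (Mus musculus) for inhibition, read by MTT assay, with a stated time of 72 h (on this read-out higher numbers stand for weaker inhibition and lower numbers for stronger inhibition), 2760 nM; compound 1 `N#Cc1c(Nc2cccc(C(F)(F)F)c2)nc(SCc2cn(Cc3ccccc3Cl)nn2)nc1-c1ccccc1` gives 3710 nM and compound 2 `N#Cc1c(Nc2ccccc2F)nc(SCc2cn(Cc3ccccc3Cl)nn2)nc1-c1ccccc1` gives 5230 nM, both within the scatter of compound 3. Compound 4 `N#Cc1c(Nc2ccccc2)nc(SCc2cn(Cc3ccccc3Cl)nn2)nc1-c1ccccc1` differs from compound 3 by hydrogen in place of methyl on an aromatic carbon. The step that bears most directly on this change is a 1.9-fold lower number from compound 2 to compound 3 (0.28 log units; within the scatter), an exchange at the same aromatic carbon; the steps of a 1.3-fold lower number from compound 1 to compound 3 (0.13 log units; within the scatter) and a 1.4-fold higher number from compound 1 to compound 2 (0.15 log units; within the scatter) exchange the whole aryl group and were likewise within the scatter. Since none of these steps exceeded the scatter, no step beyond it is expected in this assay. The expected step is a 1.3-fold higher number from compound 3 to compound 4 (0.10 log units; within the scatter). Compound 4 is therefore estimated at 3500 nM, with a range from 1500 nM to 8500 nM.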

Compound 4, half-maximal inhibitory concentration: 28300 nM
Beside the measured number, compound 4's estimate is 8.1-fold (0.91 log units) below it; measured number outside the range, above it.
By their numbers in this assay, from the lowest: compounds 3, 1 and 2 (each within the scatter of the next); then compound 4.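

The position proves not to be indifferent to substitution: in this assay, removing the methyl gives a step beyond the scatter (a 10-fold higher number from compound 3 to compound 4 (1.01 log units; beyond the scatter)), which the exchanges among substituted rings never did. Removing the fluoro (a 5.4-fold higher number from compound 2 to compound 4 (0.73 log units; beyond the scatter)) or the trifluoromethyl (a 7.6-fold higher number from compound 1 to compound 4 (0.88 log units; beyond the scatter)) also gives a step beyond the scatter, so all three substituted compounds stand apart from compound 4, which has hydrogen. Nothing shown here accounts for this difference. As far as these compounds go, it remains open whether a chlorine, a methoxy or an amine on this aromatic carbon would give numbers like those of the substituted compounds or like that of compound 4.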